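The source may report more compounds than this note shows. Statements on the series, on what has been measured and on what is new or still open speak of the compounds shown alone.

Compound 1 `CC(=O)N1N=C(c2cc(O)c(O)c([N+](=O)[O-])c2)CC1c1ccc(C#N)cc1` was tested in an assay on isolated protein for inhibition of Amine oxidase [flavin-containing] B (Homo sapiens), read by fluorescence (on this read-out higher numbers stand for weaker inhibition and lower numbers for stronger inhibition), where compound 1 gives 83200 nM. Of the two numbers in hand, compound 1 has the higher one; the other measured compound, compound 2 `O=C(/C=C/c1ccco1)c1cc(O)c(O)c([N+](=O)[O-])c1`, gives 68200 nM in this assay, and the two values lie within the usual scatter of each other, so nothing separates them. Compound 3 `CC(=O)N1N=C(c2cc(O)c(O)c([N+](=O)[O-])c2)CC1c1ccco1` has not yet been measured. It differs from compound 1 in one place: furan-2-yl in place of 4-cyanophenyl on a saturated ring carbon. Going by the values given here, no step between two measured compounds isolates this change; compound 2 also carries a furan-2-yl group, but on a core unlike that of compound 1, so its value shows only that a compound with this group reaches a similar number. Compound 3 is therefore expected to give 90000 nM (range 35000 nM to 230000 nM). The step of a 1.1-fold higher number from compound 1 to compound 3 (0.03 log units; within the scatter) is expected to be none beyond the scatter.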

Compound 3, half-maximal inhibitory concentration: 77400 nM
Compound 3: the middle estimate sits 1.2-fold (0.07 log units) above what was measured, and the stated range covers the measured number.
By their numbers in this assay, from the lowest: compounds 2, 3 and 1 (each within the scatter of the next).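

In this assay, furan-2-yl in place of 4-cyanophenyl on the saturated ring carbon gives a 1.1-fold lower number from compound 1 to compound 3 (0.03 log units; within the scatter), a step within the scatter. Compound 2 had shown only that a compound with a furan-2-yl group reaches a similar number on a different core; this step makes the comparison on one shared core. On that core, the five-membered aromatic ring with its oxygen and the six-membered carbon ring with its nitrile cannot be told apart at this position. No measurement at hand explains this result. As far as these compounds go, both groups compared here are aromatic rings, so it remains open whether an amine, a carboxylic acid or a longer alkyl chain on this carbon would give a number beyond the scatter. From the compounds shown here alone, it also remains open whether any other change to the shared core would do so.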